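Replacing 1,3-Benzothiazol-2-yl With Phenyl: Cytotoxicity Outlook

This account rests on a few compounds, and the source may have more. Where it says the series, first, only, none or still open, it means among the compounds named here.

Measured compounds:
Compound 1 `Cc1ccc(-c2nc3ccccc3s2)cc1NC(=O)c1cc([N+](=O)[O-])c(N2CCC(C(=O)O)CC2)cc1Cl` — in an ADME assay on BJ cells (Homo sapiens) for cytotoxicity, with a stated time of 72 h (a lower number here means that less compound is needed, a higher number that more compound is needed for the effect), compound 1 gives > 25000 nM, which is a limit of the assay and not a number.
Compound 2 `Cc1ccc(-c2nc3ccccc3s2)cc1NC(=O)c1cc([N+](=O)[O-])c(N(C)C)cc1Cl` — compound 2 gives > 25000 nM, also a limit.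
Compound 3 `O=C(Nc1ccc(-c2nc3ccccc3s2)cc1)c1cc([N+](=O)[O-])ccc1Cl` — compound 3 gives > 27000 nM, again a limit.

All three measured compounds sit at limits, so none of them has a readable value for cytotoxicity. Compound 3 stands at the limit of > 27000 nM in this assay, at which 1 of the 3 values shown sits, while the other two compounds stand at the limit of > 25000 nM in this assay, at which 2 of the 3 values shown sit. Among the compounds with values here, the only pair that differs in one place, compound 1 and compound 2, gives a step that the two limits leave unreadable from compound 1 to compound 2, so its size cannot be read.

Compound 4 `O=C(Nc1ccc(-c2ccccc2)cc1)c1cc([N+](=O)[O-])ccc1Cl` is not yet measured. It differs from compound 3 by phenyl in place of 1,3-benzothiazol-2-yl on an aromatic carbon. Within the data shown here, no measured step involves this change, and the one measured step is itself unreadable, so there is nothing to anchor an expected size or direction. Given that compound 3 sits at a limit, the expectation is that compound 4 also lands at or beyond a limit, with an estimated step that the limit leaves unreadable from compound 3 to compound 4. The estimate for compound 4 is 30000 nM, with a range from 8000 nM to 120000 nM, and a limit rather than a number is the most likely outcome.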

Compound 4, half-maximal effective concentration: > 27000 nM
Compound 4 was reported as a limit; the forecaster's own chance of this, stated with the estimate: 80%; the middle value is on the limit's open side.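

In this assay compound 4 gives > 27000 nM, which is a limit of the assay and not a number. Compound 3 also sits at a limit, so the step between compound 3 and compound 4 cannot be read. The compounds shown leave open whether phenyl in place of 1,3-benzothiazol-2-yl changes cytotoxicity at all, and in which direction.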